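The source may hold more compounds than are shown below. What is called first, only, known or untested is meant among the compounds shown, and "the series" means these compounds.

Compound 3 `NC1(CN(C(=O)[C@@H]2C[C@H]2c2ccccc2)c2ccc(-c3ccccc3)cc2)CCCC1` gives 0.57 nM in a functional assay for agonist activity at G protein-coupled receptor 88 (Homo sapiens), read by HTRF and cAMP accumulation (on this read-out lower numbers stand for an effect already at smaller amounts and higher numbers for an effect only at larger amounts of compound), the lowest number of the three shown, though its steps to compound 2 `CO[C@H](C)[C@H](N)CN(C(=O)[C@@H]1C[C@H]1c1ccccc1)c1ccc(-c2ccccc2)cc1` with 0.68 nM and to compound 1 `CC(C)[C@H](N)CN(C(=O)[C@@H]1C[C@H]1c1ccccc1)c1ccc(-c2ccccc2)cc1` with 1.1 nM are both within the scatter. Compound 4 `CCC(CC)C(N)CCN(C(=O)[C@@H]1C[C@H]1c1ccccc1)c1ccc(-c2ccccc2)cc1` remains unmeasured; the change from compound 3 is 2-amino-3-ethylpentyl in place of 1-aminocyclopentyl on a saturated chain carbon bound to an amide-type nitrogen. Going by the values given here, the steps that bear on this position were a 1.9-fold lower number from compound 1 to compound 3 (0.29 log units; within the scatter) and a 1.2-fold lower number from compound 2 to compound 3 (0.08 log units; within the scatter), neither beyond the scatter, so three different amine-bearing groups at this place have given nearly the same number across compounds 1, 2 and 3. For this assay a step of a 1.8-fold higher number from compound 3 to compound 4 (0.24 log units; within the scatter) is therefore expected, none beyond the scatter, in either direction. Compound 4 is estimated at 1 nM, with a range from 0.3 nM to 4 nM.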

Compound 4, half-maximal effective concentration: 2 nM
Compound 4: the middle estimate sits 2.0-fold (0.30 log units) below what was measured, and the stated range covers the measured number.
By their numbers in this assay, from the lowest: compounds 3, 2, 1 and 4 (each within the scatter of the next, the first and the last beyond it).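

In this assay this position now shows a step beyond the scatter: 2-amino-3-ethylpentyl gives a 3.5-fold higher number from compound 3 to compound 4 (0.55 log units; beyond the scatter) and a 2.9-fold higher number from compound 2 to compound 4 (0.47 log units; beyond the scatter), though both are modest, while a 1.8-fold higher number from compound 1 to compound 4 (0.26 log units; within the scatter) stays within the scatter. Read one bond further out, the change is (1-aminocyclopentyl)methyl to 3-amino-4-ethylhexyl, so loss of the ring and the longer chain arrive together and these steps do not separate them. Open, as far as these compounds go, is how a 1-aminocyclohexyl group, or a hydroxyl in place of the amine, would read here. No evidence on the cause of these steps is at hand.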